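Notes on an aryl swap at the assay limit

The source may hold more compounds than are shown below. What is called first, only, known or untested is meant among the compounds shown, and "the series" means these compounds.

In a functional assay on RT-112 cells (Homo sapiens) for antiproliferative activity, read by MTT assay, with a stated time of 72 h (on this read-out higher numbers stand for weaker inhibition of growth and lower numbers for stronger inhibition of growth), compound 1 `COc1cc(NC(=O)Nc2cccc3c(Nc4cc(OC)cc(OC)c4)ncnc23)cc(OC)c1` gives 366 nM. Compound 2 `COc1cc(Nc2ncnc3c(NC(=O)Nc4ccc(Cl)c(C(F)(F)F)c4)cccc23)cc(OC)c1` gives > 20000 nM, which is a limit of the assay and not a number. It therefore stands at the limit of > 20000 nM in this assay, at which 1 of the 2 values shown sits. Compound 3 `COc1cc(Nc2ncnc3c(NC(=O)Nc4cccc(C)c4C)cccc23)cc(OC)c1` differs from compound 2 by 2,3-dimethylphenyl in place of 4-chloro-3-(trifluoromethyl)phenyl on an amide-type nitrogen, with 2,3-dimethylphenyl on the amide-type nitrogen. Among the compounds with values here, only one measured step bears on this place: an at least 54-fold higher number from compound 1 to compound 2 (1.73 log units; beyond the scatter), which is large. A lower number is therefore expected, with the size of the step uncertain. The estimated move is an at least 6.6-fold lower number from compound 2 to compound 3 (0.82 log units; beyond the scatter). For compound 3 the expected value is 3000 nM, with an estimated range of 400 nM to 20000 nM.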

Compound 3, concentration for 50% growth inhibition: 5910 nM
Estimate against measurement, compound 3: 2.0-fold (0.29 log units) below; the measured number falls inside the stated range.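

Compound 2 gives > 20000 nM, a limit of the assay and not a number. With 2,3-dimethylphenyl on the amide-type nitrogen there is an at least 3.3-fold lower number from compound 2 to compound 3 (0.52 log units; beyond the scatter), so this position can return growth inhibition to a measurable value without 3,5-dimethoxyphenyl, yet there is still a 16-fold higher number from compound 1 to compound 3 (1.21 log units; beyond the scatter). Compound 1 therefore keeps the strongest inhibition of growth of the three.

As far as these compounds go, each swap changes several substituents at once, so which of them sets these differences stays open. From the compounds shown here alone, the true size of the step from compound 2 also stays open, and an unsubstituted phenyl or a phenyl bearing a single methoxy on the same nitrogen would give a simpler comparison.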